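A few compounds are considered here, and "the series" means these few. Any claim that something is new, unique, unknown or untested is made for them only; others in the source may bear on it.

Compound 1, `O=C1O/C(=C\Cn2cc(Cc3ccccc3)nn2)C(OCc2ccccc2)=C1OCc1ccccc1`, was tested in a functional assay on MDA-MB-231 cells (Homo sapiens) for antiproliferative activity, read by MTT assay, with a stated time of 24 h (on this read-out lower numbers stand for stronger inhibition and higher numbers for weaker inhibition), where compound 1 gives 29200 nM. Alongside it stands compound 2, `O=C1NC(O)(CCn2cc(C3=CCCCC3)nn2)C(OCc2ccccc2)=C1OCc1ccccc1`, which in this assay gives 13100 nM. Of these two numbers, compound 1 has the higher one, and the gap between the two values lies beyond the usual scatter of the measurement; compound 2 differs from compound 1 in several places at once, so nothing can be drawn from the pair about any single change.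

The next compound, compound 3, `CC(C)(C)c1ccc(-c2cn(C/C=C3\OC(=O)C(OCc4ccccc4)=C3OCc3ccccc3)nn2)cc1`, has not yet been measured in this assay. It differs from compound 1 in one place: 4-(tert-butyl)phenyl in place of benzyl on an aromatic carbon. Going by the values given here, no measured pair shows the effect of this kind of change, so the expectation rests on little. Compound 3 is expected to sit close to compound 1, with a step from compound 1 to compound 3 of a 1.3-fold lower number from compound 1 to compound 3 (0.12 log units; within the scatter), not clearly beyond the scatter in either direction. The estimate for compound 3 in this assay is 22000 nM, with a range from 7000 nM to 70000 nM.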

Compound 3, half-maximal inhibitory concentration: 51200 nM
The estimate for compound 3 lay 2.3-fold (0.37 log units) below the measured number, and the stated range covers the measured number.
By their numbers in this assay, from the lowest: compound 2; then compounds 1 and 3 (each within the scatter of the next).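

Going by these compounds alone, replacing benzyl with 4-(tert-butyl)phenyl on an aromatic carbon of the five-membered aromatic ring with 3 nitrogen is the first single change that can be read in this assay and it comes to a 1.8-fold higher number from compound 1 to compound 3 (0.24 log units; within the scatter) in this read-out. This position therefore takes a group of 10 heavy atoms in place of one of 7, both with a six-membered aromatic ring of carbon only, and the number shows no clear shift in either direction. No further measurement that could explain this outcome is at hand. As far as these compounds go, it remains open whether a different kind of group on this carbon, such as an amine, a carboxylic acid or a longer chain, would move the number beyond the scatter. From the compounds shown here alone, it is also open whether the same replacement would give a similar step on the core of compound 2.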